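The compounds below may be only part of what the source reports. "The series", "measured", "known", "first", "only" and "open" are said of these compounds alone.

Measured compounds:
compound 1, `C[Si](C)(C)C#Cc1cc(-c2nc3ccccc3s2)ccc1N`: 560 nM
compound 2, `C#Cc1cc(-c2nc3ccc(F)cc3s2)ccc1N`: 23 nM

Of the compounds shown here, two have been tested in a functional assay on MDA-MB-468 cells (Homo sapiens) for inhibition, with a stated time of 72 h; on this read-out higher numbers stand for weaker inhibition of growth and lower numbers for stronger inhibition of growth. Compound 1 gives 560 nM, and compound 2 gives 23 nM. Compound 2 thus holds the lower of the two numbers, and its distance from compound 1 lies beyond the usual scatter of this assay. Going by the values given here, the two structures differ in more than one place, so no single step connects them, and their values can only be set side by side.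

The next compound, compound 3, has the structure `C[Si](C)(C)C#Cc1cc(-c2nc3ccc(F)cc3s2)ccc1N`. It differs from compound 2 at a single point: a group of 4 heavy atoms (3 carbon, 1 silicon; no ring) in place of a hydrogen atom, on a triple-bonded carbon.

Among the compounds with values here, no measured step of this exact kind is known, so the expected size of the step from compound 2 to compound 3 in this assay rests on the spread of the two values alone. Compound 3 is expected to lie between the two, most likely closer to compound 1, because compound 1 gives 560 nM. The step expected here is a 13-fold higher number from compound 2 to compound 3 (1.12 log units; beyond the scatter), a rise beyond the scatter. Compound 3 is estimated at 300 nM, within a range from 70 nM to 1300 nM.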

Compound 3, concentration for 50% growth inhibition: 400 nM
Compound 3: the middle estimate sits 1.3-fold (0.12 log units) below what was measured; low and high end bracket the measured number.
By their numbers in this assay, from the lowest: compound 2; then compounds 3 and 1 (each within the scatter of the next).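

In this assay, the end of the triple bond proves sensitive: a group of 4 heavy atoms (3 carbon, 1 silicon; no ring) in place of a hydrogen atom, on a triple-bonded carbon, gives a 17-fold higher number from compound 2 to compound 3 (1.24 log units; beyond the scatter), which means much weaker inhibition of growth. By contrast, fluoro in place of hydrogen on an aromatic carbon, with the silicon-bearing group present on both compounds, gives a 1.4-fold lower number from compound 1 to compound 3 (0.15 log units; within the scatter), so this change has no effect that can be told apart from the scatter in this setting. The large gap seen earlier, which no single step could explain, therefore now has one clear single-change step behind it, at the triple-bonded carbon, although the data offer no measured explanation for the size of that step.

On these data alone, it remains open whether fluoro would also make so little difference with a hydrogen atom on the triple-bonded carbon. It is also unclear whether the silicon atom itself matters, or whether a methyl group or a tert-butyl group at that carbon would weaken growth inhibition just as much.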